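A few compounds are considered here, and "the series" means these few. Any claim that something is new, unique, unknown or untested is made for them only; others in the source may bear on it.

Three compounds share one core and differ only in the halogen-bearing phenyl ring on the outer amide nitrogen. Compound 1 `CN(C)C(=O)c1cc2cnc(Nc3ccc(NC(=O)C4(C(=O)Nc5ccc(Br)cc5)CC4)cc3)nc2n1C1CCCC1` carries a 4-bromophenyl there; in a functional assay on NCI-H1299 cells (Homo sapiens) for inhibition, read by CCK-8 assay, with a stated time of 72 h, tested at 1 uM (a lower number here means less inhibition of growth, a higher number more inhibition of growth at the concentration tested), compound 1 gives 27.6%. Compound 2 `CN(C)C(=O)c1cc2cnc(Nc3ccc(NC(=O)C4(C(=O)Nc5cccc(Cl)c5)CC4)cc3)nc2n1C1CCCC1` carries a 3-chlorophenyl, and in this assay compound 2 gives 47.9%. Compound 3 `CN(C)C(=O)c1cc2cnc(Nc3ccc(NC(=O)C4(C(=O)Nc5cccc(Br)c5)CC4)cc3)nc2n1C1CCCC1` carries a 3-bromophenyl, and in this assay compound 3 gives 46.6%. Among these three numbers compound 3 stands second highest: compound 2 is nearest, and the gap a number 1.3 percentage points lower from compound 2 to compound 3 (within the scatter) lies within the scatter, so the two cannot be ordered; compound 1 is furthest, the gap a number 19 percentage points higher from compound 1 to compound 3 (beyond the scatter) being beyond the scatter.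

Compound 4 `CN(C)C(=O)c1cc2cnc(Nc3ccc(NC(=O)C4(C(=O)Nc5cccc(F)c5)CC4)cc3)nc2n1C1CCCC1` is not yet measured. It differs from compound 3 by fluoro in place of bromo on an aromatic carbon. The step that bears most directly on this is the exchange of one halogen for another at the same place on the ring, where a number 1.3 percentage points lower from compound 2 to compound 3 (within the scatter) stayed within the scatter. The larger steps of a number 20.3 percentage points higher from compound 1 to compound 2 (beyond the scatter) and a number 19 percentage points higher from compound 1 to compound 3 (beyond the scatter) came from relocating the halogen, not from swapping it. For compound 4 a small step at most is therefore expected, a number 2.6 percentage points lower from compound 3 to compound 4 (within the scatter). Compound 4 is expected to give about 44% in this assay, within a range of 30% to 58%.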

Compound 4, percent growth inhibition at one concentration: 64.2%
Compound 4: the middle estimate sits 20.2 percentage points below what was measured; measured number above the stated range.
By their numbers in this assay, from the lowest: compound 1; then compounds 3 and 2 (each within the scatter of the next); then compound 4.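

The earlier chloro and bromo pair suggested that the choice of halogen at this place on the ring hardly matters, but fluoro changes that picture: in this assay there is a number 17.6 percentage points higher from compound 3 to compound 4 (beyond the scatter) and also a number 16.3 percentage points higher from compound 2 to compound 4 (beyond the scatter). Swapping one halogen for another here can therefore move growth inhibition as clearly as relocating the halogen did, although this holds for fluoro alone, since chloro and bromo cannot be ordered. Taken as a single change, 3-fluorophenyl in place of 4-bromophenyl gives a number 36.6 percentage points higher from compound 1 to compound 4 (beyond the scatter) and is the only step in this set large enough to be graded large, while nothing presented explains why fluoro behaves differently from the other two halogens.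

The compounds shown leave open whether the gain belongs to fluoro specifically or would also appear with a plain phenyl ring, or with a methyl, methoxy or nitrile group at the same place. They also leave open how much of the difference from compound 1 comes from the halogen's place and how much from its identity, a question that 4-fluorophenyl on the same amide nitrogen would help to separate.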